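Undoing a Hydroxy Chain Change on the Shared Core

The source may report more compounds than this note shows. Statements on the series, on what has been measured and on what is new or still open speak of the compounds shown alone.

Two compounds share a core and differ in one place. Compound 1 `CC(=O)N1CCN(CCN2CCC(CNC(=O)c3cccc4[nH]c(C(C)C)nc34)CC2)CC1` carries the (4-acetylpiperazin-1-yl)methyl group, and compound 2 `CC(=O)N(C)CC(O)CN1CCC(CNC(=O)c2cccc3[nH]c(C(C)C)nc23)CC1` carries 2-(acetyl(methyl)amino)-1-hydroxyethyl in its place. In a functional assay for agonist activity at 5-hydroxytryptamine receptor 4 (Homo sapiens), read by cAMP accumulation (on this read-out higher numbers stand for larger maximal responses and lower numbers for smaller maximal responses), compound 1 gives 76%, while compound 2 gives 64%, the lower of the two numbers, with the step of a number 12 percentage points lower from compound 1 to compound 2 (beyond the scatter). Compound 3 `COC(=O)N1CCN(CCN2CCC(CNC(=O)c3cccc4[nH]c(C(C)C)nc34)CC2)CC1` is not yet measured. It differs from compound 2 as follows: (4-(methoxycarbonyl)piperazin-1-yl)methyl in place of 2-(acetyl(methyl)amino)-1-hydroxyethyl on a saturated chain carbon bound to an amine nitrogen in a ring. This change largely reverses the earlier one: a piperazinylmethyl group returns where the hydroxy chain stood, and only the acetyl of compound 1 is exchanged for a methoxycarbonyl. Going by the values given here, the one step that bears on it, a number 12 percentage points lower from compound 1 to compound 2 (beyond the scatter), points to a rise of about the same size. Compound 3 is therefore expected to give 76%, between 62% and 88%. That estimate amounts to an expected a number 12 percentage points higher from compound 2 to compound 3 (beyond the scatter).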

Compound 3, intrinsic activity: the largest response reached, in percent of the reference agonist's: 72%
Estimate against measurement, compound 3: 4 percentage points above; measured number inside the range.
By their numbers in this assay, from the lowest: compounds 2, 3 and 1 (each within the scatter of the next, the first and the last beyond it).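

In this assay, methoxy in place of methyl on a carbonyl carbon gives a number 4 percentage points lower from compound 1 to compound 3 (within the scatter), so the new compound shows that this end of the piperazine group accepts either group without a clear change in maximal response. Exchanging the hydroxy chain for (4-(methoxycarbonyl)piperazin-1-yl)methyl gives a number 8 percentage points higher from compound 2 to compound 3 (within the scatter), so this pair, unlike compound 1 and compound 2, shows no difference that clears the usual scatter. No supporting measurement explains these results.

The hydroxy chain and the piperazine ring differ in several features at once, so these compounds cannot show which feature matters. Also open, going by these compounds, is how the maximal response would respond to an ethoxy or dimethylamino group on that carbonyl carbon, or to a piperazine with a free amine in place of the acylated nitrogen.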